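The source may hold more compounds than are shown below. What is called first, only, known or untested is meant among the compounds shown, and "the series" means these compounds.

Measured compounds in a functional assay on PC-3 cells (Homo sapiens) for inhibition, read by MTT assay, with a stated time of 72 h; on this read-out higher numbers stand for weaker inhibition and lower numbers for stronger inhibition:
compound 1 `O=C(CSc1nc(Nc2ccccc2)c2ccccc2n1)Nc1cccc([N+](=O)[O-])c1`: 11800 nM
compound 2 `CCc1cccc(NC(=O)CSc2nc(Nc3ccccc3)c3ccccc3n2)c1`: 11000 nM
compound 3 `O=C(CSc1nc(Nc2ccccc2)c2ccccc2n1)Nc1ccc(F)cc1`: 9560 nM

Compound 1 gives the highest of the three numbers, yet its nearest neighbour is reached by a 1.1-fold lower number from compound 1 to compound 2 (0.03 log units; within the scatter) and its furthest by a 1.2-fold lower number from compound 1 to compound 3 (0.09 log units; within the scatter); both steps lie within the scatter, so no ranking of the three can be read from them. The remaining pair, a 1.2-fold lower number from compound 2 to compound 3 (0.06 log units; within the scatter), is within the scatter as well. Every measured step, like the one followed here, alters the part of the molecule that is exchanged in the present step while the shared core is kept, and none of them moves the number beyond the scatter.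

Compound 4 `O=C(CSc1nc(Nc2ccccc2)c2ccccc2n1)Nc1ccc(Cl)cc1Cl` has not yet been measured in this assay. Its difference from compound 1 is 2,4-dichlorophenyl in place of 3-nitrophenyl on an amide-type nitrogen. The three steps that bear on it, all variations at the same position and all within the scatter, give no ground for expecting a step beyond the scatter in either direction in this assay. The expected step is therefore a 1.2-fold lower number from compound 1 to compound 4 (0.09 log units; within the scatter), essentially no change. For compound 4 the estimate is 9500 nM, with a range from 4000 nM to 22000 nM.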

Compound 4, half-maximal inhibitory concentration: 9110 nM
Compound 4: the middle estimate sits 1.0-fold (0.02 log units) above what was measured, within the range that was stated.
By their numbers in this assay, from the lowest: compounds 4, 3, 2 and 1 (each within the scatter of the next).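

In this assay, the change to 2,4-dichlorophenyl on the amide-type nitrogen gives a 1.3-fold lower number from compound 1 to compound 4 (0.11 log units; within the scatter) and a 1.0-fold lower number from compound 3 to compound 4 (0.02 log units; within the scatter) and also a 1.2-fold lower number from compound 2 to compound 4 (0.08 log units; within the scatter) as its steps, so all three stay within the scatter. The earlier compounds shown here carry a single substituent on this phenyl ring, while compound 4 carries two chlorine atoms, and this second substituent does not take the number beyond the scatter of any of the three earlier compounds, which extends the flat picture at this position from singly substituted to doubly substituted phenyl rings. No measurement is available that bears on why the number stays level across these groups.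

As far as these compounds go, whether a carboxylic acid or a dimethylamino group on this phenyl ring, or a saturated ring such as cyclohexyl in place of it, would move the number beyond the scatter remains open. All four compounds also keep the shared core unchanged, so the response to any change away from this amide-type nitrogen is open as well.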